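The source may hold more compounds than are shown below. What is called first, only, known or untested is meant among the compounds shown, and "the series" means these compounds.

Measured in a functional assay on the whole organism (brain) with Mus musculus as the target; on this read-out higher numbers stand for an effect only at larger amounts of compound and lower numbers for an effect already at smaller amounts:

- Compound 1 `O=[N+]([O-])c1ccc(SCCc2c[nH]cn2)nc1`: 2.6 mg/kg
- Compound 2 `COC(=O)c1ccc(OCCc2c[nH]cn2)cc1`: > 3 mg/kg
- Compound 3 `Clc1cc(Cl)cc(OCCc2c[nH]cn2)c1`: > 10 mg/kg

Among the compounds with values here, compound 1 gives 2.6 mg/kg, the only true number among the three. Compound 2 is reported as > 3 mg/kg, which is a limit and not a number. Compound 3 is reported as > 10 mg/kg, and this too is a limit. The position of compound 2 is therefore only partly known, and its real value could lie well away from the limit.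

Compound 4 `Cc1ccc(OCCc2c[nH]cn2)cc1` has not yet been measured. It keeps the structure of compound 2 except for one change: methyl in place of methoxycarbonyl on an aromatic carbon, para to a group of 8 heavy atoms (methyl in place of methoxycarbonyl on an aromatic carbon). Within the data shown here, no two measured compounds differ in one place only, so no measured step can serve as a guide.

Compound 1 at 2.6 mg/kg shows that a real number can be obtained among these compounds. Two of the three results, however, are limits. In this assay, the expected change, a step that the limit leaves unreadable from compound 2 to compound 4, is estimated to stay within the usual scatter, with no firm direction. For compound 4 the estimated value is 5 mg/kg, with an expected range from 1.5 mg/kg to 15 mg/kg.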

Compound 4, dose for half-maximal effect: 2.3 mg/kg
Beside the measured number, compound 4's estimate is 2.2-fold (0.34 log units) above it, and the stated range covers the measured number.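

At this place on the aromatic ring, methyl in place of methoxycarbonyl gives a true number in this assay, with compound 4 at 2.3 mg/kg as its result. Compound 2 has only a limit, and how far the step really reaches cannot be read because of it: the limit of > 3 mg/kg in this assay, at which 1 of the 4 values shown sits. On these data alone, what can be read is an at least 1.3-fold lower number from compound 2 to compound 4 (0.11 log units; that floor lies within the scatter) and nothing more, so the shared core with the small methyl group still gives an effect at a dose that can be measured, while the true size of the step stays unknown.

The compounds shown leave open how other groups at this same place would read, such as an amine, a carboxylic acid or a single chlorine atom, and therefore whether methyl is a special case or one of many groups that would serve here. Also open, as far as these compounds go, is what a longer chain between the oxygen and the rest of the core would do, and what sulfur in place of that oxygen would do to compound 4 alone.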